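A smaller carbonyl group replaces the hydroxypropyl arm

The compounds below may be only part of what the source reports. "The series", "measured", "known", "first", "only" and "open" are said of these compounds alone.

Measured in an assay on membranes from HEK293 cells for displacement of a labelled ligand from D(4) dopamine receptor (Homo sapiens), read by scintillation counting, with a stated time of 60 min; a higher number here means a weaker inhibitor, a lower number a stronger inhibitor:
compound 1, `OC(Cc1ccccc1)CN1CCC(NCCSC(c2ccc(F)cc2)c2ccc(F)cc2)CC1`, gives 2200 nM.
compound 2, `O=C(c1ccccc1)N1CCC(NCCSC(c2ccc(F)cc2)c2ccc(F)cc2)CC1`, gives 4110 nM.
compound 3, `O=C(c1ccc(F)cc1)N1CCC(NCC[S+]([O-])C(c2ccc(F)cc2)c2ccc(F)cc2)CC1`, gives only a limit of this assay, > 100000 nM.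

Among the two plain numbers compound 1 has the lower one, and its nearest neighbour is compound 2, reached by a 1.9-fold higher number from compound 1 to compound 2 (0.27 log units; within the scatter), so the two cannot be told apart. Compound 3 differs from both in more than one place and sits at the limit of > 100000 nM in this assay, at which 1 of the 3 values shown sits, so it says nothing about a single change.

Compound 4, `CC(C)(C)C(=O)N1CCC(NCCSC(c2ccc(F)cc2)c2ccc(F)cc2)CC1`, is the next compound to be measured. It differs from compound 1 by (tert-butyl)carbonyl in place of 2-hydroxy-3-phenylpropyl on an amine nitrogen in a ring. Within the data shown here, the one measured step that bears on this is a 1.9-fold higher number from compound 1 to compound 2 (0.27 log units; within the scatter), where the same arm was also exchanged for a carbonyl-linked group on the ring nitrogen, and the number moved only within the scatter. The change to compound 4 is of the same kind, so the expected step in this assay is small, toward a slightly higher number at most: compound 4 is expected at 4000 nM, within 1500 nM to 12000 nM, which would mean a 1.8-fold higher number from compound 1 to compound 4 (0.26 log units; within the scatter).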

Compound 4, inhibition constant: 11900 nM
Estimate against measurement, compound 4: 3.0-fold (0.47 log units) below; measured number inside the range.
By their numbers in this assay, from the lowest: compounds 1 and 2 (each within the scatter of the next); then compound 4. At a limit, above all of these: compound 3.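

In this assay, among these compounds, the group on the carbonyl carbon turns out to matter: tert-butyl in place of phenyl gives a 2.9-fold higher number from compound 2 to compound 4 (0.46 log units; beyond the scatter) and is the first single change here to move the number beyond the scatter. The earlier step from the 2-hydroxy-3-phenylpropyl arm to benzoyl could not be told from scatter, whereas (tert-butyl)carbonyl in place of that arm gives a 5.4-fold higher number from compound 1 to compound 4 (0.73 log units; beyond the scatter) as a modest but readable loss. A carbonyl on this ring nitrogen therefore does not by itself keep the number near that of compound 1, and among these three compounds, the two whose arm holds a six-membered aromatic ring have the lower numbers, while compound 4, with no ring in that group, has the higher one.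

Three compounds cannot show whether the ring itself or simply the replacement of tert-butyl is what counts, and a cyclohexyl group, a methyl group or an amine-bearing chain on the carbonyl would be needed to separate these readings. No measurement shown bears on why tert-butyl gives the higher number.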